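Working notes: from compound 1 to compound 3

This account rests on a few compounds, and the source may have more. Where it says the series, first, only, none or still open, it means among the compounds named here.

Measured so far in an ADME assay on microsomes from liver (Rattus norvegicus) for metabolic stability (a lower number here means that the compound disappears faster, a higher number that the compound lasts longer), are these compounds:
- compound 1 `CC(C)[C@@H](c1ccc(-c2ccc3cccc(F)c3c2)[nH]c1=O)[C@@H]1OC(=O)NC1=O` gives 1.27 h
- compound 2 `O=C1NC(=O)/C(=C/C(c2ccc(-c3ccc4cccc(F)c4c3)[nH]c2=O)C2CCCCC2)O1` gives 2.39 h

Among the measured compounds shown here, compound 1 stands within the usual scatter of compound 2, so the two values set no order and neither compound stands apart. Compound 3 `CC(C)[C@H](C[C@H]1OC(=O)NC1=O)c1ccc(-c2ccc3cccc(F)c3c2)[nH]c1=O` is not yet measured. It differs from compound 1 by one change ((2,4-dioxo-1,3-oxazolidin-5-yl)methyl in place of 2,4-dioxo-1,3-oxazolidin-5-yl on a saturated chain carbon bound to an aromatic carbon and a saturated chain carbon): (2,4-dioxo-1,3-oxazolidin-5-yl)methyl in place of 2,4-dioxo-1,3-oxazolidin-5-yl on a saturated chain carbon bound to an aromatic carbon and a saturated chain carbon.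

No measured pair isolates this change, so nothing shown gives its size directly. For the measured compounds named here, the only guide is the narrow spread of the data: compound 2 at 2.39 h and compound 1 at 1.27 h lie within the scatter of each other. In this assay the expected step (a 1.2-fold higher number from compound 1 to compound 3 (0.07 log units; within the scatter)) is none beyond the scatter, with no direction favoured. Compound 3 is expected to give a half-life of 1.5 h (estimated range 0.7 h to 3.2 h)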

Compound 3, half-life: 0.95 h
Compound 3: middle estimate off by 1.6-fold (0.20 log units), on the high side; the measured number falls inside the stated range.
By their numbers in this assay, from the lowest: compounds 3, 1 and 2 (each within the scatter of the next, the first and the last beyond it).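

Among the compounds shown here, the pair of compound 1 and compound 3 gives the first direct reading of this position in this assay: with (2,4-dioxo-1,3-oxazolidin-5-yl)methyl in place of 2,4-dioxo-1,3-oxazolidin-5-yl on a saturated chain carbon bound to an aromatic carbon and a saturated chain carbon, the step is a 1.3-fold lower number from compound 1 to compound 3 (0.13 log units; within the scatter). Since this step lies within the scatter, the half-life does not separate the two compounds, and the group with 8 heavy atoms and the group with 7 cannot be told apart in this assay. No measurement shown bears on the reason for this reading.

A single pair at this place leaves open whether a longer chain carrying the same 2,4-dioxo-1,3-oxazolidin-5-yl ring, or an amine or a carboxylic acid in its place, would give a step beyond the scatter. It also leaves open whether the same replacement would read the same way on the core of compound 2, which has no matched partner among the compounds shown.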